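This account rests on a few compounds, and the source may have more. Where it says the series, first, only, none or still open, it means among the compounds named here.

In an assay on CHO cells for binding affinity to Substance-P receptor (Homo sapiens) (on this read-out higher numbers stand for weaker inhibition and lower numbers for stronger inhibition), the measured compounds are:
compound 1 `CCCCCN(CCCCC)C(=O)[C@H]1CCN(C(=O)N(c2ccccc2)c2ccccc2)[C@H](C(=O)O)C1`, 33 nM;
compound 2 `CCCCCN(CCCCC)C(=O)[C@H]1CCN(C(=O)N(c2ccccc2)c2ccccc2)[C@H](C(=O)NCCNCC(N)=O)C1`, 13 nM;
compound 3 `CCCCCN(CCCCC)C(=O)[C@H]1CCN(C(=O)N(c2ccccc2)c2cccc(Cl)c2)[C@H](C(=O)NCCNCC(N)=O)C1`, 3.5 nM.

Compound 2 holds the second highest of the three numbers: a 2.5-fold lower number from compound 1 to compound 2 (0.40 log units; beyond the scatter), and a 3.7-fold lower number from compound 2 to compound 3 (0.57 log units; beyond the scatter). Compound 4 `CCCCCN(CCCCC)C(=O)[C@H]1CCN(C(=O)N(c2ccccc2)c2ccccc2)[C@H](C(=O)NCCN(CC(N)=O)Cc2ccccc2OC)C1` differs from compound 2 by 2-methoxybenzyl in place of hydrogen on an amine nitrogen. For the measured compounds named here, no measured step touches that amine nitrogen. Going by the values given here, the only step in the same region of the molecule, a 2.5-fold lower number from compound 1 to compound 2 (0.40 log units; beyond the scatter), was modest, and the step of a 3.7-fold lower number from compound 2 to compound 3 (0.57 log units; beyond the scatter) concerns an aromatic carbon elsewhere, so it gives no direct guidance. The expectation is therefore a small step in this assay, likely within or close to the scatter, with no firm direction. The step of a 1.3-fold lower number from compound 2 to compound 4 (0.11 log units; within the scatter) is the estimate. Compound 4 is expected near 10 nM, within 3 nM to 35 nM.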

Compound 4, half-maximal inhibitory concentration: 1.8 nM
Estimate against measurement, compound 4: 5.6-fold (0.74 log units) above; the measured number lies below the stated range.
By their numbers in this assay, from the lowest: compounds 4 and 3 (each within the scatter of the next); then compound 2; then compound 1.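

In this assay the amine nitrogen proves open to substitution: 2-methoxybenzyl in place of hydrogen gives a 7.2-fold lower number from compound 2 to compound 4 (0.86 log units; beyond the scatter) and the number falls, even with 9 more heavy atoms and an aromatic ring at this site. For the compounds shown here, this is the first evidence that changes on this nitrogen, and not only on the carbonyl carbon or the aromatic carbon, move the read-out. Nothing at hand explains the step.

From the compounds shown here alone, whether a plain benzyl or a 2-hydroxybenzyl on this nitrogen would give a similar step remains open. Also open, going by these compounds, is whether 2-methoxybenzyl and chloro would add up within one compound.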